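The source may report more compounds than this note shows. Statements on the series, on what has been measured and on what is new or still open speak of the compounds shown alone.

Compound 1, `Cn1c(-c2ccc(NC(=O)CSc3nc4cc(Cl)ccc4o3)cc2)nc(-c2ccccc2)c1-c1ccccc1`, gives 2.4% in a functional assay on MCF7 cells (Homo sapiens) for cytotoxicity, read by MTT assay, with a stated time of 24 h, tested at 0.64 ug/mL; on this read-out higher numbers stand for a stronger effect at the one concentration tested and lower numbers for a weaker effect.
Compound 2, `Cn1c(-c2ccc(NC(=O)CSc3nc4ccccc4s3)cc2)nc(-c2ccccc2)c1-c1ccccc1`, gives 0.9% in this assay.
Compound 3, `Cn1c(-c2ccc(NC(=O)CSC3=NCCS3)cc2)nc(-c2ccccc2)c1-c1ccccc1`, gives 10.3% in this assay.

All three compounds share the same core and differ only in the ring that hangs on the sulfur. Compound 3 stands a number 7.9 percentage points higher from compound 1 to compound 3 (within the scatter) and a number 9.4 percentage points higher from compound 2 to compound 3 (within the scatter); both gaps lie within the scatter, so on these numbers the three compounds cannot be told apart. Compound 4, `Cn1ccnc1SCC(=O)Nc1ccc(-c2nc(-c3ccccc3)c(-c3ccccc3)n2C)cc1`, is the next compound in this series and has not yet been measured. It differs from compound 3 in this way: a group of 6 heavy atoms (4 carbon, 2 nitrogen; one five-membered aromatic ring with 2 hetero atoms) in place of a group of 5 heavy atoms (3 carbon, 1 nitrogen, 1 sulfur; one five-membered non-aromatic ring with 2 hetero atoms), on a sulfur.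

Within the data shown here, the steps that bear on this change are the two that swap the group on the same sulfur, a number 7.9 percentage points higher from compound 1 to compound 3 (within the scatter) and a number 9.4 percentage points higher from compound 2 to compound 3 (within the scatter), and both stayed within the scatter even though the groups exchanged differed in size and in whether the ring was aromatic. Nothing in these data points to a step beyond the scatter in this assay for another ring on this sulfur. Compound 4 is therefore expected to give about 4%, within a range of 0% to 13%. This estimate means a step of a number 6.3 percentage points lower from compound 3 to compound 4 (within the scatter), which is expected to stay within the scatter.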

Compound 4, a percentage reported as activity, at one concentration (the size of the read-out at that concentration, not a potency): 10.3%
The estimate for compound 4 lay 6.3 percentage points below the measured number; the measured number falls inside the stated range.
By their numbers in this assay, from the lowest: compounds 2, 1, 3 and 4 (each within the scatter of the next).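

In this assay, putting 1-methyl-1H-imidazol-2-yl on this sulfur gives no change at the digits printed from compound 3 to compound 4 (within the scatter). Among these compounds, this is the first pair here that compares two single five-membered rings, one non-aromatic and one aromatic, and on this read-out the two cannot be told apart. Against the larger groups with two rings, the same 1-methyl-1H-imidazol-2-yl gives a number 9.4 percentage points higher from compound 2 to compound 4 (within the scatter) and a number 7.9 percentage points higher from compound 1 to compound 4 (within the scatter), so all four compounds now lie within the scatter of one another, whether the group on the sulfur has one ring or two, and whether that ring is aromatic or not. No measurement is at hand that would explain these numbers.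

As far as these compounds go, all four groups on this sulfur are rings, so it remains open whether an open chain such as ethyl, or a chain ending in a carboxylic acid or an amine, would also stay within the scatter. Every number also comes from a single concentration, which leaves open how these compounds would compare across a range of concentrations.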